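The compounds below may be only part of what the source reports. "The series", "measured", "known", "first", "only" and "open" are said of these compounds alone.

The account follows the step from compound 1 `C=CCN(C)c1nc(N)nc2c1ncn2[C@H]1C[C@H](N=[N+]=[N-])[C@@H](CO)O1` to compound 4 `CN(C)c1nc(N)nc2c1ncn2[C@H]1C[C@H](N=[N+]=[N-])[C@@H](CO)O1`. In an ADME assay on Vero cells (Chlorocebus sabaeus) for cytotoxicity, with a stated time of 5 days (a higher number here means a weaker inhibitor, a lower number a stronger inhibitor), compound 1 gives 32000 nM. Compound 2 `[N-]=[N+]=N[C@H]1C[C@H](n2cnc3c(N)nc(F)nc32)O[C@@H]1CO` gives 34400 nM in this assay, a value that sits within the usual scatter of the value of compound 1, so the two are not told apart. Compound 3 `COc1nc(N)c2ncn([C@H]3C[C@H](N=[N+]=[N-])[C@@H](CO)O3)c2n1` reaches only the limit of the assay, > 100000 nM. That limit is the limit of > 100000 nM in this assay, at which 1 of the 3 values shown sits. Going by the values given here, the one measured step, an at least 2.9-fold higher number from compound 2 to compound 3 (0.46 log units; beyond the scatter), concerns a different kind of change and does not bear on the step from compound 1 to compound 4, which is hydrogen in place of vinyl on a saturated chain carbon bound to a nitrogen on an aromatic ring, with vinyl leaving and hydrogen entering. Among the compounds with values here, no measured step involves such a change, so the only guide is the closeness of compound 1 and compound 2, and the expectation is of no step beyond the scatter. Compound 4 is therefore estimated at 35000 nM, within a range from 15000 nM to 90000 nM, in this assay. That estimate means a step of a 1.1-fold higher number from compound 1 to compound 4 (0.04 log units; within the scatter) which is expected to stay within the scatter.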

Compound 4, half-maximal inhibitory concentration: > 100000 nM
Compound 4: a limit, no number; the forecaster's own chance of this, stated with the estimate: 15%; at least 2.8-fold (0.45 log units) between middle value and limit.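

In this assay, shortening allyl(methyl)amino to dimethylamino gives an at least 3.1-fold higher number from compound 1 to compound 4 (0.49 log units; beyond the scatter), so a change on a saturated chain carbon bound to a nitrogen on an aromatic ring can move this read-out beyond the scatter. The earlier compounds shown here showed a step only for methoxy in place of fluoro on an aromatic carbon, and none showed what a change in this chain does. Compound 4 gives > 100000 nM, which is a limit and not a number, so the step has a lower bound but no known size, and the limit is now shared more widely: the limit of > 100000 nM in this assay, at which 2 of the 4 values shown sit.

The compounds shown leave open whether a saturated propyl chain in place of allyl would read like allyl or like methyl. They also leave open how an ethyl group or a cyclopropyl ring would read at this place.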